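The source may hold more compounds than are shown below. What is called first, only, known or untested is meant among the compounds shown, and "the series" means these compounds.

Compound 1 (`Cc1cc(NC(=O)Nc2ccccc2OC(F)(F)F)c2ccccc2n1`) gives > 25000 nM, a limit
Compound 2 (`Cc1cc(NC(=O)Nc2ccc(F)c(F)c2)c2ccccc2n1`) gives > 25000 nM, a limit
Compound 3 (`Cc1cc(NC(=O)Nc2cc(F)cc(F)c2)c2ccccc2n1`) gives > 25000 nM, a limit

All three readings come from an ADME assay on BJ cells (Homo sapiens) for cytotoxicity, with a stated time of 72 h; on this read-out higher numbers stand for an effect only at larger amounts of compound and lower numbers for an effect already at smaller amounts. None of them is an exact number, so the compounds cannot be ranked against one another. Compound 1 stands at the limit of > 25000 nM in this assay, at which 3 of the 3 values shown sit. Compound 2 and compound 3 share that same limit.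

Compound 4 (`CSc1ccccc1NC(=O)Nc1cc(C)nc2ccccc12`) has not yet been measured. It keeps the core of compound 1 but carries methylsulfanyl in place of trifluoromethoxy on an aromatic carbon. The group sits on a six-membered aromatic ring of carbon only, ortho to a large group.

Among the compounds with values here, no measured step between two compounds is available to show what a change like this does here, so the expectation rests on the readings alone. Compound 1, the starting point of this change, gives > 25000 nM, which is a limit. Compound 2 and compound 3 reach the same limit despite carrying different groups, so no shift beyond the usual scatter is expected. The expected size of the change is a number no higher from compound 1 to compound 4 (the limit leaves the size open). Compound 4 is estimated at 25000 nM, with an expected range from 12000 nM to 50000 nM. The assay may well report only a limit again.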

Compound 4, half-maximal effective concentration: > 25000 nM
Compound 4: a limit, no number; the forecaster's own chance of this, stated with the estimate: 80%; the middle value sits exactly at the limit.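

Compound 1 and compound 4 both give only a limit, not a number, in this assay, so the change from trifluoromethoxy to methylsulfanyl cannot be read as a step. The compounds shown leave open at what concentration, if any, each would affect these cells, since all of them stop at the same point: the limit of > 25000 nM in this assay, at which 4 of the 4 values shown sit.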